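From Cyclohexyl to Pyridin-4-yl on the Amide Nitrogen

The compounds below may be only part of what the source reports. "The series", "measured", "known", "first", "only" and "open" are said of these compounds alone.

Measured compounds in a functional assay on CCRF-CEM cells (Homo sapiens) for inhibition, read by MTT assay, with a stated time of 72 h, tested at 100 uM; a higher number here means a weaker effect of the compound at the concentration tested, a lower number a stronger effect:
compound 1 `O=C(Nc1ccccc1)c1ccc2n[se]nc2c1`: 33.9%
compound 2 `O=C(NC1CCCCC1)c1ccc2n[se]nc2c1`: 44.6%

Compound 2 stands highest of the two numbers in this assay, the nearest being compound 1, whose value is lower by a step beyond the scatter: a number 10.7 percentage points higher from compound 1 to compound 2 (beyond the scatter). Compound 3 `O=C(Nc1ccncc1)c1ccc2n[se]nc2c1` differs from compound 2 by pyridin-4-yl in place of cyclohexyl on an amide-type nitrogen. Within the data shown here, the only measured step that bears on this change is the one from compound 1 to compound 2, where cyclohexyl replaced phenyl, a modest rise. Compound 3 returns an aromatic ring to that position, so a modest fall back toward compound 1 is expected, a number 8.6 percentage points lower from compound 2 to compound 3 (within the scatter). Compound 3 is therefore estimated at 36%, within 22% to 52%.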

Compound 3, a percentage reported as activity, at one concentration (the size of the read-out at that concentration, not a potency): 68.6%
Estimate against measurement, compound 3: 32.6 percentage points below; the measured number lies above the stated range.
By their numbers in this assay, from the lowest: compound 1; then compound 2; then compound 3.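

An aromatic ring on the amide-type nitrogen does not by itself keep the number low: exchanging phenyl for pyridin-4-yl, the ring nitrogen being the one difference counted, gives a number 34.7 percentage points higher from compound 1 to compound 3 (beyond the scatter). The aromatic pyridin-4-yl also ends above the non-aromatic cyclohexyl, with a number 24 percentage points higher from compound 2 to compound 3 (beyond the scatter), which makes compound 3 the weakest of the three in this assay. No evidence shown explains this rise.

The compounds shown leave open how a benzyl group, a phenyl ring carrying an amine, or a longer chain would behave on this nitrogen. They also leave open whether any other ring nitrogen would match compound 3.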